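From Fluoro to Ethoxy on the Ethyl Ester

A few compounds are considered here, and "the series" means these few. Any claim that something is new, unique, unknown or untested is made for them only; others in the source may bear on it.

In a functional assay on the whole organism (strain Sprague-Dawley) for inhibition, with Rattus norvegicus as the target, with a stated time of 10 min (a higher number here means that more compound is needed for the effect, a lower number that less compound is needed), compound 1 (`O=C(O)c1cnc(-c2ccccc2F)[nH]c1=O`) gives 5 mg/kg. Compound 2 (`COc1cccc(-c2ncc(C(=O)O)c(=O)[nH]2)c1`) gives 10 mg/kg. Compound 3 (`CCOC(=O)c1cnc(-c2ccccc2F)[nH]c1=O`) reaches only a limit in this assay, > 10 mg/kg. Compound 4 (`CCOC(=O)c1cnc(-c2ccccc2OCC)[nH]c1=O`) carries ethoxy in place of fluoro on an aromatic carbon, ortho to a large group: ethoxy in place of fluoro on an aromatic carbon. For the measured compounds named here, the one measured step, an at least 2.0-fold higher number from compound 1 to compound 3 (0.30 log units; that floor lies within the scatter), concerns the ester rather than this position, and its floor lies within the scatter. Going by the values given here, no measured step alters the fluoro group, so the data offer no size or direction for this change, and no shift beyond the scatter is expected. The expected step is a step that the limit leaves unreadable from compound 3 to compound 4. For compound 4 the estimated value is 12 mg/kg, with an expected range of 3 mg/kg to 40 mg/kg.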

Compound 4, dose for 50% inhibition: 2 mg/kg
Estimate against measurement, compound 4: 6.0-fold (0.78 log units) above; the whole stated range lies above it.
By their numbers in this assay, from the lowest: compound 4; then compounds 1 and 2 (each within the scatter of the next).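

On the ethyl ester, ethoxy in place of fluoro on an aromatic carbon, ortho to a large group, gives an at least 5.0-fold lower number from compound 3 to compound 4 (0.69 log units; beyond the scatter) in this assay. For the compounds shown here, this is the first measured change at this position, and it shows that the number responds to the group placed there, even with the ester in place. The full size of the step cannot be read, since compound 3 is held only by a limit: the limit of > 10 mg/kg in this assay, at which 1 of the 4 values shown sits.

On these data alone, whether a longer chain such as propoxy, or an amine, would serve this position as well remains open. So does whether ethoxy would have the same effect alongside the free carboxylic acid.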